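A few compounds are considered here, and "the series" means these few. Any claim that something is new, unique, unknown or untested is made for them only; others in the source may bear on it.

Measured compounds: compound 1 `C[C@H]1[C@H](NCc2cncs2)C[C@H]2C[C@@H]1C2(C)C` with > 100000 nM; compound 2 `C[C@H]1[C@H](NCc2sccc2C2CC2)C[C@H]2C[C@@H]1C2(C)C` with 25000 nM.

Compound 1 carries only a limit in an ADME assay on MDCK cells (Canis lupus familiaris) for cytotoxicity, read by microscopy, with a stated time of 48 h; a higher number here means that more compound is tolerated, a lower number that less compound is tolerated: compound 1 gives > 100000 nM, which is a limit of the assay rather than a number. Compound 2 gives 25000 nM in this assay. Among the values shown, compound 1 stands at the limit of > 100000 nM in this assay, at which 1 of the 2 values shown sits, while compound 2 sits clearly lower; no step between these two is computed, so only the two values themselves can be compared.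

Compound 3 `C[C@H]1[C@H](NCc2cc(Br)cs2)C[C@H]2C[C@@H]1C2(C)C` has not yet been measured in this assay. It differs from compound 1 by 4-bromothiophen-2-yl in place of 1,3-thiazol-5-yl on a saturated chain carbon bound to an amine nitrogen. Going by the values given here, no measured step supports this change, so the expectation rests on the two values alone, with compound 2 at 25000 nM offering the only number. The expected step is an at least 2.5-fold lower number from compound 1 to compound 3 (0.39 log units; beyond the scatter), downward and beyond the usual scatter. Compound 3 is estimated at 40000 nM, with a range from 12000 nM to 150000 nM.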

Compound 3, minimum cytotoxic concentration: 6250 nM
The estimate for compound 3 lay 6.4-fold (0.81 log units) above the measured number, and the stated range ends above it.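

In this assay, going by these compounds alone, the exchange of 1,3-thiazol-5-yl for 4-bromothiophen-2-yl on a saturated chain carbon bound to an amine nitrogen gives the first step that can be read in one place: an at least 16-fold lower number from compound 1 to compound 3 (1.20 log units; beyond the scatter). The tolerated concentration therefore responds strongly to the aromatic group at this place, even with the core of compound 1 unchanged. As far as these compounds go, the true size of the step remains open, because compound 1 carries a limit and not a number: the limit of > 100000 nM in this assay, at which 1 of the 3 values shown sits.

The step cannot yet be divided between the bromine and the exchange of the ring itself; a plain thiophen-2-yl or a 4-chlorothiophen-2-yl at this place would separate the two. Also open, from the compounds shown here alone, is how a carboxylic acid or a longer chain on the same ring would change the tolerated concentration.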